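The compounds below may be only part of what the source reports. "The series", "measured", "known", "first", "only" and "open" are said of these compounds alone.

Measured compounds:
Compound 1 `Cc1cc(Oc2ccc(-c3ccn4c(CC5CC5)nnc4c3Cl)cc2F)ccn1` — 251 nM
Compound 2 `Clc1cc(-c2ccn3c(CC4CC4)nnc3c2Cl)ccc1NC1CCOCC1` — 148 nM
Compound 3 `FC(F)(F)c1c(-c2ccc(NC3CCOCC3)c(Cl)c2)ccn2c(CC3CC3)nnc12` — 18.6 nM

In a functional assay on cells for positive allosteric modulation of metabotropic glutamate receptor 2 (Homo sapiens), read by scintillation counting and GTPgammaS binding, with a stated time of 30 min (on this read-out higher numbers stand for an effect only at larger amounts of compound and lower numbers for an effect already at smaller amounts), compound 3 stands with the lowest of the three numbers. For the measured compounds named here, its nearest neighbour is compound 2, which differs in one place and gives 148 nM; the step of an 8.0-fold lower number from compound 2 to compound 3 (0.90 log units; beyond the scatter) is the only single change that has been measured here. Compound 1 differs from compound 3 in several places; in this assay compound 1 gives 251 nM, and nothing more than that can be read from the pair.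

Compound 4 `O[C@H]1CC[C@H](Oc2ccc(-c3ccn4c(CC5CC5)nnc4c3C(F)(F)F)cc2Cl)CC1` is not yet measured. It differs from compound 3 at the aromatic carbon that carries the (oxan-4-yl)amino group: (4-hydroxycyclohexyl)oxy in place of (oxan-4-yl)amino on an aromatic carbon. Going by the values given here, no measured step bears on this change: the one step in hand concerns the trifluoromethyl group on the shared core, not the group on the outer ring, and the outer-ring change between compound 1 and compound 2 comes with other differences. The expectation for this assay therefore rests on compound 3 alone, with no reason from the data to expect a step beyond the scatter in either direction.

Compound 4 is thus estimated at about 35 nM, with a range from 10 nM to 130 nM. That estimate corresponds to an expected step of a 1.9-fold higher number from compound 3 to compound 4 (0.27 log units; within the scatter).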

Compound 4, half-maximal effective concentration: 25.1 nM
Estimate against measurement, compound 4: 1.4-fold (0.14 log units) above, within the range that was stated.
By their numbers in this assay, from the lowest: compounds 3 and 4 (each within the scatter of the next); then compounds 2 and 1 (each within the scatter of the next).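

In this assay, (4-hydroxycyclohexyl)oxy in place of (oxan-4-yl)amino on the aromatic carbon ortho to a chloro group and para to a large group gives a 1.3-fold higher number from compound 3 to compound 4 (0.13 log units; within the scatter), the only single change at this position among the compounds shown. The result shows that this position accepts a ring of carbon only, carrying its own hydroxy group and attached through oxygen, with no step beyond the scatter, while the counts of hydrogen-bond donors and acceptors stay the same; the swap of the ring, the linking atom and the added stereocentres come as one change, so their separate contributions cannot be told apart. The data offer no measured basis for explaining this result.

From the compounds shown here alone, it remains open whether an amine, a carboxylic acid or a longer chain in place of the hydroxy group on the cyclohexyl ring would keep the number in the same range. Going by these compounds, it is also open whether chloro in place of trifluoromethyl on the shared core would matter with this outer group as it does with the (oxan-4-yl)amino group, where the change gives an 8.0-fold lower number from compound 2 to compound 3 (0.90 log units; beyond the scatter).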